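Swapping chloro for methoxy on compound 1

The compounds below may be only part of what the source reports. "The series", "measured", "known", "first", "only" and "open" are said of these compounds alone.

Compound 1 `Clc1ccc(Nc2ccc(N3CC4CC(C3)N4)cn2)cc1` is the stronger of the two measured compounds: in an assay on cell membranes for displacement of a labelled ligand from Neuronal acetylcholine receptor; alpha4/beta2 (Rattus norvegicus) (a higher number here means a weaker inhibitor, a lower number a stronger inhibitor), compound 1 gives 2.49 nM. Compound 2 `COc1ccc(Nc2ccc(N3CC4CC(C3)N4)nn2)cc1`, which carries methoxy and a different core, gives 578 nM in this assay. Compound 3 `COc1ccc(Nc2ccc(N3CC4CC(C3)N4)cn2)cc1` keeps the core of compound 1 and differs from it by methoxy in place of chloro on an aromatic carbon. Among the compounds with values here, no measured pair shows this exact change, so the expected step from compound 1 to compound 3 is a modest loss, a 3.2-fold higher number from compound 1 to compound 3 (0.51 log units; beyond the scatter), possibly within the scatter. For compound 3 the estimate in this assay is 8 nM, with a range from 2 nM to 40 nM.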

Compound 3, inhibition constant: 7.3 nM
Compound 3: middle estimate off by 1.1-fold (0.04 log units), on the high side; measured number inside the range.
By their numbers in this assay, from the lowest: compound 1; then compound 3; then compound 2.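

In this assay the swap of chloro for methoxy, para to a large group, is a modest step: a 2.9-fold higher number from compound 1 to compound 3 (0.47 log units; beyond the scatter). Compound 2 carries methoxy together with a different core, whereas methoxy on the core of compound 1 is found in compound 3, and compound 3 gives 7.3 nM, so methoxy alone does not lift the number to that of compound 2, 578 nM. Nothing here explains the size of this step.

This single pair leaves open how an amine, a carboxylic acid or a longer chain such as ethoxy would fare at this position.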